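Shortening the Side Group of Compound 2

This account rests on a few compounds, and the source may have more. Where it says the series, first, only, none or still open, it means among the compounds named here.

In a functional assay on MDA-MB-231 cells (Homo sapiens) for inhibition, read by MTT assay, with a stated time of 48 h (on this read-out lower numbers stand for stronger inhibition and higher numbers for weaker inhibition), compound 1 (`COc1ccc(N(C)c2nc(C)nc3ccccc23)cc1OCCCCCC[Se]C#N`) gives 3550 nM, compound 2 (`COc1ccc(N(C)c2nc(C)nc3ccccc23)cc1C(=O)OCCCC[Se]C#N`) gives 554 nM, and compound 3 (`Cc1nc(N(C)c2ccc([Se]C#N)c(Cl)c2)c2ccccc2n1`) gives 9 nM. Compound 2 therefore stands in the middle, with the second highest of the three numbers.

Compound 4 (`COc1ccc(N(C)c2nc(C)nc3ccccc23)cc1[Se]C#N`) has not yet been measured. It differs from compound 2 in one place: a group of 3 heavy atoms (1 carbon, 1 nitrogen, 1 selenium; no ring) in place of a group of 10 heavy atoms (6 carbon, 1 nitrogen, 2 oxygen, 1 selenium; no ring), on an aromatic carbon. The new group lies on an aromatic carbon of a six-membered aromatic ring of carbon only, ortho to a methoxy group.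

Two pieces of evidence bear on this change. Within the data shown here, the only measured step, a 6.4-fold lower number from compound 1 to compound 2 (0.81 log units; beyond the scatter), exchanges one long group for another on an aromatic carbon, and it is modest but beyond the scatter. It shows that this place responds to change, though it does not involve the shorter group. Compound 3, at 9 nM, carries the same group of 3 heavy atoms on an aromatic carbon, but it differs from compound 2 elsewhere too, so it is only a loose guide.

Together they point towards a lower number, and the expected step is an 11-fold lower number from compound 2 to compound 4 (1.04 log units; beyond the scatter). The estimated value for compound 4 is 50 nM, with an expected range of 8 nM to 350 nM.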

Compound 4, half-maximal inhibitory concentration: 52 nM
Estimate against measurement, compound 4: 1.0-fold (0.02 log units) below, within the range that was stated.
By their numbers in this assay, from the lowest: compound 3; then compound 4; then compound 2; then compound 1.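

In this assay, putting the group of 3 heavy atoms on this aromatic carbon, ortho to a methoxy group, in place of the ester-bearing group of 10 heavy atoms gives an 11-fold lower number from compound 2 to compound 4 (1.03 log units; beyond the scatter). Against the other group of 10 heavy atoms, the change gives a 68-fold lower number from compound 1 to compound 4 (1.83 log units; beyond the scatter), so at this place the short group stands well below both long groups, and each of these steps is larger than the one between the two long groups. Nothing in the available evidence accounts for this difference.

The compounds shown do not tell whether the number changes gradually or abruptly with the length of the group, which a group with a short chain of one or two carbons between the ring and the selenium would help to settle, nor whether the selenium itself matters, which a thiocyanate or a plain nitrile at this place would test. They also leave open how much the neighbouring methoxy group contributes, a question that a hydroxyl or an ethoxy group in its place could address.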